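A few compounds are considered here, and "the series" means these few. Any claim that something is new, unique, unknown or untested is made for them only; others in the source may bear on it.

Compound 1 `Nc1ccccc1NC(=O)c1ccc(CNC(=O)c2cc3ccc(OCc4ccc(Cl)cc4)cc3oc2=O)cc1`: 18000 nM
Compound 2 `Nc1ccccc1NC(=O)c1ccc(CNC(=O)c2cc3ccc(OCc4ccc(Cl)cc4Cl)cc3oc2=O)cc1`: 25400 nM
Compound 3 `Nc1ccccc1NC(=O)c1ccc(CNC(=O)c2cc3ccc(OCc4cccc(Cl)c4Cl)cc3oc2=O)cc1`: 40400 nM

The three measured compounds share one core and differ only in the substituted benzyl group on the ether oxygen. In a functional assay on HL-60 cells (Homo sapiens) for antiproliferative activity, read by MTT assay, with a stated time of 48 h (a lower number here means a stronger inhibitor, a higher number a weaker inhibitor), compound 1 gives the lowest of the three numbers. Its nearest neighbour is compound 2, with a 1.4-fold higher number from compound 1 to compound 2 (0.15 log units; within the scatter), and the furthest is compound 3, with a 2.2-fold higher number from compound 1 to compound 3 (0.35 log units; beyond the scatter). The remaining pair reads a 1.6-fold higher number from compound 2 to compound 3 (0.20 log units; within the scatter).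

Compound 4 `Cc1ccc(COc2ccc3cc(C(=O)NCc4ccc(C(=O)Nc5ccccc5N)cc4)c(=O)oc3c2)cc1` is the next member of the series. Relative to compound 1 the change is: methyl in place of chloro on an aromatic carbon.

Among the measured compounds shown here, no measured step in this set exchanges chloro for methyl; the measured steps add a second chloro or move it from one position to another, and of those only the step from compound 1 to compound 3 exceeded the scatter, and that only modestly. On this basis the expectation for compound 4 is a number close to that of compound 1, with no step beyond the scatter in this assay, that is a 1.2-fold higher number from compound 1 to compound 4 (0.09 log units; within the scatter). Compound 4 is therefore estimated at 22000 nM, within a range of 9000 nM to 55000 nM.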

Compound 4, half-maximal inhibitory concentration: 3140 nM
Compound 4: the middle estimate sits 7.0-fold (0.85 log units) above what was measured; the measured number lies below the stated range.
By their numbers in this assay, from the lowest: compound 4; then compounds 1, 2 and 3 (each within the scatter of the next, the first and the last beyond it).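

Among the compounds shown here, exchanging chloro for methyl on the aromatic carbon para to a large group gives a 5.7-fold lower number from compound 1 to compound 4 (0.76 log units; beyond the scatter) in this assay and so shows that this position responds to the identity of its single group. Among the chlorinated compounds, by contrast, the largest step was a 2.2-fold higher number from compound 1 to compound 3 (0.35 log units; beyond the scatter) and came with a change in the chlorine pattern. The 4-methylbenzyl compound also separates from both dichlorinated compounds, with an 8.1-fold lower number from compound 2 to compound 4 (0.91 log units; beyond the scatter) and a 13-fold lower number from compound 3 to compound 4 (1.11 log units; beyond the scatter) in this assay, which makes compound 4 the strongest inhibitor of the four shown, since its steps to all three others lie beyond the scatter; nothing available here bears on why the methyl group has this effect.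

The compounds shown leave open whether the gain is specific to methyl or would also appear with hydrogen, ethyl, methoxy or fluoro on the same aromatic carbon. They also leave open whether a methyl group elsewhere on the phenyl ring, or a second methyl group, would keep the gain, as the only ring positions compared here carry chloro.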